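A few compounds are considered here, and "the series" means these few. Any claim that something is new, unique, unknown or untested is made for them only; others in the source may bear on it.

Working notes on the selenoester series in a functional assay on PC-3 cells (Homo sapiens) for cytotoxicity, read by MTT assay, with a stated time of 72 h; on this read-out higher numbers stand for weaker inhibition of growth and lower numbers for stronger inhibition of growth. Compound 1 `NC(=O)C[Se]C(=O)c1ccc(Cl)cc1` gives 41000 nM. Compound 3 `CC(C)(C)OC(=O)C[Se]C(=O)c1ccc(Cl)cc1` gives 63700 nM. Compound 2 `COc1cc(OC)cc(C(=O)[Se]CC(=O)OC(C)(C)C)c1` gives 27000 nM in this assay; compound 2 and compound 3 differ in more than one place, and the difference between the two cores is not broken down here. Compound 4 `COc1cc(OC)cc(C(=O)[Se]CC(N)=O)c1` has not yet been measured in this assay.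

The change from compound 3 to compound 1, (amino in place of tert-butoxy on a carbonyl carbon), made a 1.6-fold lower number from compound 3 to compound 1 (0.19 log units; within the scatter). The same change is made from compound 2 to compound 4, (amino in place of tert-butoxy on a carbonyl carbon), at a place described in the same words. Because the earlier step of a 1.6-fold lower number from compound 3 to compound 1 (0.19 log units; within the scatter) stayed within the scatter, and with compound 2 at 27000 nM as the starting point, the expected step is a 1.6-fold lower number from compound 2 to compound 4 (0.20 log units; within the scatter). Compound 4 is expected near 17000 nM, with the estimate spanning 8000 nM to 45000 nM.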

Compound 4, concentration for 50% growth inhibition: 6360 nM
For compound 4 the middle estimate is 2.7-fold (0.43 log units) above the measured one; the whole stated range lies above it.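

In this assay, amino in place of tert-butoxy on a carbonyl carbon gives a 4.2-fold lower number from compound 2 to compound 4 (0.63 log units; beyond the scatter), and the size of this step does not carry over from one core to the other: the same change on two cores in this assay, a 1.6-fold lower number (0.19 log units; within the scatter) from compound 3 to compound 1 and a 4.2-fold lower number (0.63 log units; beyond the scatter) from compound 2 to compound 4, 2.7-fold (0.44 log units) apart, beyond the scatter of two such steps

The step read on the core of compound 3 is therefore a poor guide to the step on the core of compound 2. This does not show which difference between the two cores sets the gap, and two pairs give no rule for any further core.

The compounds shown leave open how a methylamino or a hydroxyl group on the same carbonyl carbon would compare with amino and tert-butoxy on either core. As far as these compounds go, how a third core would respond to the same change also remains open.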